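A Chloro Substituent Where Trifluoromethyl Abolished Binding

The source may report more compounds than this note shows. Statements on the series, on what has been measured and on what is new or still open speak of the compounds shown alone.

Compound 1 `CNC(=O)c1sc(N2CC3CC2(CNC(=O)c2c[nH]c4ncc(C(F)(F)F)cc24)C3)nc1C(F)(F)F`: > 100000 nM
Compound 2 `CNC(=O)c1sc(N2CC3CC2(CNC(=O)c2c[nH]c4ncccc24)C3)nc1C(F)(F)F`: 2000 nM
Compound 3 `Cc1cc(N(C)C)ccc1-c1nnc(N(C)Cc2ccc3nccn3c2)o1`: > 100000 nM
Compound 4 `CNC(=O)c1sc(N2CC3CC2(CNC(=O)c2c[nH]c4ncc(Cl)cc24)C3)nc1C(F)(F)F`: not yet measured

In an assay on isolated protein for inhibition of tyrosine-protein kinase receptor TYRO3 (Homo sapiens), read by LC-MS, with stated times of 30 min and 180 min (a lower number here means a stronger inhibitor, a higher number a weaker inhibitor), compound 2 gives 2000 nM. Within the data shown here, that is the only actual number among the three measured compounds. For compound 1 the result is a limit of the assay, > 100000 nM. For compound 3 the result is likewise a limit, > 100000 nM. Two of the three values therefore sit at the same limit (the limit of > 100000 nM in this assay, at which 2 of the 3 values shown sit), so compound 2 stands alone as the one measurable binder.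

Compound 4 differs from compound 2 in one place: chloro in place of hydrogen on an aromatic carbon. Among the measured compounds shown here, the only measured step that bears on this position is an at least 50-fold lower number from compound 1 to compound 2 (1.69 log units; beyond the scatter), where removing the trifluoromethyl from that same aromatic carbon moved the compound from the limit to a measurable value. Chloro is a smaller group than trifluoromethyl, but it occupies the same site on the ring, so a weaker result than compound 2 is expected, though probably not as severe as for compound 1. The estimate for compound 4 is 15000 nM, with a range of 3000 nM to 100000 nM, which corresponds to an expected step of a 7.5-fold higher number from compound 2 to compound 4 (0.88 log units; beyond the scatter).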

Compound 4, half-maximal inhibitory concentration in the tyrosine-protein kinase receptor TYRO3 assay: 631 nM
Beside the measured number, compound 4's estimate is 24-fold (1.38 log units) above it; measured number below the stated range.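

In the tyrosine-protein kinase receptor TYRO3 assay, the aromatic carbon two atoms from the ring nitrogen accepts a substituent and keeps measurable binding: chloro in place of hydrogen gives a 3.2-fold lower number from compound 2 to compound 4 (0.50 log units; beyond the scatter), so the loss seen with trifluoromethyl does not extend to every group on this carbon. In the tyrosine-protein kinase receptor TYRO3 assay, between the two groups on the same carbon the difference is an at least 150-fold lower number from compound 1 to compound 4 (2.19 log units; beyond the scatter), and this step starts from a limit of the assay, held by compound 1: the limit of > 100000 nM in the tyrosine-protein kinase receptor TYRO3 assay, at which 2 of the 4 values shown sit.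

In a physicochemical assay for solubility (on this read-out higher numbers stand for higher solubility and lower numbers for lower solubility), compound 2 gives < 1600 nM, which is a limit of the assay: the limit of < 1600 nM in the physicochemical assay, at which 1 of the 2 values shown sits. In the physicochemical assay, compound 4 gives 2000 nM. In the physicochemical assay, the step of an at least 1.2-fold higher number from compound 2 to compound 4 (0.09 log units; that floor lies within the scatter) has a floor within the scatter and shows no change in solubility.

With only hydrogen, chloro and trifluoromethyl to compare on this carbon, the compounds shown leave open where fluoro, methyl, methoxy or a nitrile would fall. They also leave open whether the step from hydrogen to chloro would hold if the methyl amide of the shared core were replaced by a carboxylic acid or a longer chain.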